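The compounds below may be only part of what the source reports. "The series", "measured", "known", "first", "only" and "open" are said of these compounds alone.

In a functional assay on NCI-H1650 cells (Homo sapiens) for cytotoxicity, read by MTT assay, with a stated time of 48 h (a higher number here means a weaker inhibitor, a lower number a stronger inhibitor), compound 1, with the structure `CCCCOc1ccc2c(Cl)ccnc2c1`, gives 2570 nM. Compound 2, with the structure `CCCCCCCCOc1ccc2c(Cl)ccnc2c1`, carries the change butyl in place of hydrogen on a saturated chain carbon, four bonds along the chain from an oxygen on an aromatic ring relative to compound 1, and in this assay compound 2 gives 3240 nM. The step that this change made, a 1.3-fold higher number from compound 1 to compound 2 (0.10 log units; within the scatter), lies within the scatter of the measurement. Compound 3 has the structure `CCOc1ccc2c(NCCN(C)C)ccnc2c1`; its core and that of compound 1 differ in more than one place, and the difference between the two cores is not broken down here. In this assay compound 3 gives 3490 nM, a number that sits within the scatter of both compound 2 and compound 1, so no order among the three can be read from these values.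

Compound 4, with the structure `CCCCCCOc1ccc2c(NCCN(C)C)ccnc2c1`, has not yet been measured. It differs from compound 3 by butyl in place of hydrogen on a saturated chain carbon, two bonds along the chain from an oxygen on an aromatic ring. Among the measured compounds shown here, this is the same kind of change as the one from compound 1 to compound 2, but not the same: there the butyl entered four bonds along the chain from an oxygen on an aromatic ring, here it enters two bonds along the chain from that oxygen. Because the earlier step of a 1.3-fold higher number from compound 1 to compound 2 (0.10 log units; within the scatter) stayed within the scatter, the step from compound 3 to compound 4 in this assay is expected to be of a similar small size, a 1.1-fold higher number from compound 3 to compound 4 (0.06 log units; within the scatter). On that basis compound 4 is estimated to give 4000 nM, with a likely range from 1800 nM to 9000 nM.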

Compound 4, half-maximal inhibitory concentration: 930 nM
Estimate against measurement, compound 4: 4.3-fold (0.63 log units) above; the whole stated range lies above it.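

In this assay, the butyl change does not carry over from one core to the other as a step of fixed size: the same change on two cores in this assay, a 1.3-fold higher number (0.10 log units; within the scatter) from compound 1 to compound 2 and a 3.8-fold lower number (0.57 log units; beyond the scatter) from compound 3 to compound 4, 4.7-fold (0.67 log units) apart, beyond the scatter of two such steps On the core of compound 3, the change gives a 3.8-fold lower number from compound 3 to compound 4 (0.57 log units; beyond the scatter), so a step that stayed within the scatter on the core of compound 1 cannot be taken as a guide to the size of the step on the core of compound 3. This does not show that the core alone sets the difference, since the two steps also differ in place, with the butyl entering four bonds along the chain from the oxygen in one case and two bonds along it in the other, and each step rests on a single pair of compounds.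

The compounds shown leave open whether the core or the place where the butyl enters accounts for the gap, and a matched pair with the same chains on both cores would be needed to separate the two. They also leave open how the core of compound 3 responds to a longer chain, to a chain carrying an amine or a carboxylic acid, or to a chain closed into a cyclohexyl ring.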